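The source may hold more compounds than are shown below. What is called first, only, known or untested is meant among the compounds shown, and "the series" means these compounds.

Measured so far in a functional assay on A549 cells (Homo sapiens) for antiproliferative activity, read by MTT assay, with a stated time of 48 h; a lower number here means a stronger inhibitor, a higher number a weaker inhibitor:
compound 1, `CC(=O)O[C@]1(C)/C=C/C(=O)/C(CO)=C\C[C@](C)(CCC=C(C)C)/C=C/[C@H]1OC(=O)C=C(C)C`, gives 3150 nM
compound 2, `CC(C)=CCC[C@]1(C)/C=C/[C@@H](OC(=O)C=C(C)C)[C@](C)(O)/C=C/C(=O)/C(CN(C)C)=C\C1`, gives 590 nM

Of these two, compound 2 has the lower number in this assay, and compound 1 sits well above it, with a gap that is beyond the usual scatter. Going by the values given here, compounds 1 and 2 differ in more than one place, so no single step connects them; only their two values can be set side by side.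

Compound 3, `CC(C)=CCC[C@]1(C)/C=C/[C@@H](OC(=O)C=C(C)C)[C@](C)(O)/C=C/C(=O)/C(C(=O)N(C(C)C)C(C)C)=C\C1`, has not yet been measured. It differs from compound 2 in one place: diisopropylcarbamoyl in place of (dimethylamino)methyl on a double-bonded ring carbon. Among the compounds with values here, no pair among the measured compounds tests this exchange, so its direction has no precedent here. A moderate weakening is expected for this step, a 2.5-fold higher number from compound 2 to compound 3 (0.41 log units; beyond the scatter), with a range wide enough to include no change beyond the scatter. Compound 3 is estimated at 1500 nM, between 400 nM and 6000 nM.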

Compound 3, half-maximal inhibitory concentration: 13500 nM
For compound 3 the middle estimate is 9.0-fold (0.95 log units) below the measured one; the whole stated range lies below it.
By their numbers in this assay, from the lowest: compound 2; then compound 1; then compound 3.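

In this assay, the double-bonded ring carbon proves sensitive to the group it carries: diisopropylcarbamoyl in place of (dimethylamino)methyl gives a 23-fold higher number from compound 2 to compound 3 (1.36 log units; beyond the scatter). This is the first single-place change among these compounds, and it shows that, at this position, the entering group of 9 heavy atoms, with its carbonyl, goes with a much weaker inhibitor than the leaving group of 4 heavy atoms. No measurement given here accounts for this loss.

On these data alone, the step changes the carbonyl and the nitrogen substituents together, so it remains open which of these goes with the weakening. As far as these compounds go, a (diisopropylamino)methyl group or a dimethylcarbamoyl group at this carbon would separate the two, and how either would read in this assay remains unknown.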